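Compound 4 Expected to Stay at the Assay Limit

The source may hold more compounds than are shown below. What is called first, only, known or untested is meant among the compounds shown, and "the series" means these compounds.

Compound 3 `CCOC(=O)C1=Cc2ccccc2OC1(OCc1cn(-c2cccc(C(F)(F)F)c2)nn1)C(F)(F)F` carries a 3-(trifluoromethyl)phenyl on the aromatic nitrogen of the shared core. In a functional assay on HeLa cells (Homo sapiens) for inhibition, read by MTT assay, with a stated time of 24 h (on this read-out higher numbers stand for weaker inhibition and lower numbers for stronger inhibition), compound 3 gives only a limit, > 150000 nM. Compound 1 `CCOC(=O)C1=Cc2ccccc2OC1(OCc1cn(CC(=O)Nc2cccc(F)c2)nn1)C(F)(F)F` also gives only a limit in this assay, > 150000 nM. Compound 2 `CCOC(=O)C1=Cc2ccccc2OC1(OCc1cn(CC(=O)Nc2ccccc2Br)nn1)C(F)(F)F` likewise gives only a limit, > 150000 nM. All three values sit at the same limit (the limit of > 150000 nM in this assay, at which 3 of the 3 values shown sit), so compound 3 cannot be placed above or below its two neighbours on the numbers shown.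

Compound 4 `CCOC(=O)C1=Cc2ccccc2OC1(OCc1cn(CC(=O)Nc2ccc(I)cc2Cl)nn1)C(F)(F)F` differs from compound 3 in one place: ((2-chloro-4-iodophenyl)carbamoyl)methyl in place of 3-(trifluoromethyl)phenyl on an aromatic nitrogen. The measured steps that bear on this change are a step that the two limits leave unreadable from compound 1 to compound 3 and a step that the two limits leave unreadable from compound 2 to compound 3, together with a step that the two limits leave unreadable from compound 1 to compound 2 between the two compounds that carry an amide-type nitrogen. None of these steps has a readable size, because all three compounds sit at the limit of > 150000 nM in this assay, at which 3 of the 3 values shown sit. Compounds 1 and 2, whose groups on the aromatic nitrogen also contain an amide-type nitrogen, show only the limit, so compound 4 is expected to reach only the limit as well, with a step that the limit leaves unreadable from compound 3 to compound 4 expected to be unreadable. The estimate for compound 4 in this assay is 200000 nM, with a range from 100000 nM to 500000 nM.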

Compound 4, half-maximal inhibitory concentration: 26100 nM
Beside the measured number, compound 4's estimate is 7.7-fold (0.88 log units) above it; measured number below the stated range.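

In this assay, the group on the aromatic nitrogen can move a compound off the limit, as the change from 3-(trifluoromethyl)phenyl to ((2-chloro-4-iodophenyl)carbamoyl)methyl gives an at least 5.7-fold lower number from compound 3 to compound 4 (0.75 log units; beyond the scatter). The amide-type nitrogen alone does not account for this, since compounds 1 and 2 also carry it and go against any such pattern; with that nitrogen kept, changing only its aryl group gives an at least 5.7-fold lower number from compound 2 to compound 4 (0.75 log units; beyond the scatter) and an at least 5.7-fold lower number from compound 1 to compound 4 (0.75 log units; beyond the scatter), so among these compounds the readable value appears only with 2-chloro-4-iodophenyl. These three sizes are minimums, the steps among compounds 1, 2 and 3 still cannot be read, and the remaining compounds all stay at one assay limit: the limit of > 150000 nM in this assay, at which 3 of the 4 values shown sit.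

The compounds shown leave open whether the chlorine, the iodine or the two together go with the step, as a 2-chlorophenyl or a 4-iodophenyl on the same amide-type nitrogen would show. Also open, on these data alone, is how an amine or a carboxylic acid on that phenyl ring, or a longer chain in place of the methyl link, would read in this assay.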